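The source may report more compounds than this note shows. Statements on the series, on what has been measured and on what is new or still open speak of the compounds shown alone.

Measured so far:
compound 1, `COc1ccc(/C(C)=C(\C)C(=O)NC2CC2)cc1`, in a toxicity assay on the whole organism (strain Icem-CET (SPF Caw)) for cytotoxicity, with Mus musculus as the target (a lower number here means that less compound is needed, a higher number that more compound is needed for the effect), gives 250 mg/kg;
compound 2, `C#CCNC(=O)/C(C)=C(\C)c1ccc(C)cc1`, in this assay gives 120 mg/kg.

Compound 2 stands at the lowest of the two numbers in this assay, and its nearest neighbour is compound 1, whose number is higher by a margin that goes beyond the usual scatter of this kind of measurement. Compound 3, `C#CCNC(=O)/C(C)=C(\C)c1ccc(OC)cc1`, has not yet been measured in this assay. It differs from compound 2 in one place: methoxy in place of methyl on an aromatic carbon. Within the data shown here, no step between measured compounds describes this change, so the size of the effect is open. Compound 1 also carries a methoxy group on its ring, and in this assay compound 1 gives 250 mg/kg, which is the only hint available. The step from compound 2 to compound 3 in this assay is expected to be small, at most around the edge of the scatter, and to lean upward, that is a 1.4-fold higher number from compound 2 to compound 3 (0.15 log units; within the scatter). Compound 3 is therefore estimated at 170 mg/kg in this assay, with a range from 90 mg/kg to 320 mg/kg.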

Compound 3, dose for half-maximal effect: 150 mg/kg
Beside the measured number, compound 3's estimate is 1.1-fold (0.05 log units) above it; measured number inside the range.
By their numbers in this assay, from the lowest: compounds 2, 3 and 1 (each within the scatter of the next, the first and the last beyond it).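

In this assay, methoxy in place of methyl on an aromatic carbon, para to a large group, gives a 1.3-fold higher number from compound 2 to compound 3 (0.10 log units; within the scatter), so at this position the added oxygen and hydrogen-bond acceptor bring no change that can be told apart from repeat measurement. On the amide-type nitrogen, with the methoxy group unchanged, propargyl in place of cyclopropyl gives a 1.7-fold lower number from compound 1 to compound 3 (0.22 log units; within the scatter), so neither single change on its own moves the number beyond the scatter. No measurement at hand bears on why these steps are small. From the compounds shown here alone, whether an amine or a carboxylic acid on that aromatic carbon would give a step beyond the scatter remains open. Also open, going by these compounds, is how a longer chain on the amide-type nitrogen would read in this assay.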